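Aryl ester variation on a pyrazole carboxylate series

This account rests on a few compounds, and the source may have more. Where it says the series, first, only, none or still open, it means among the compounds named here.

Of the compounds shown here, two of the shared core have been measured. Compound 1 `O=C(c1cn(-c2ccccc2)nc1-c1cccnc1)N1CCC(Cc2ccccc2)CC1` carries an amide; in a functional assay on Raji cells (Homo sapiens) for cytotoxicity, read by MTT assay, with a stated time of 48 h (on this read-out lower numbers stand for stronger inhibition and higher numbers for weaker inhibition), compound 1 gives 8120 nM. Compound 2 `CC(C)c1cccc(OC(=O)c2cn(-c3ccccc3)nc2-c2cccnc2)c1` carries an ester instead; in this assay compound 2 gives 11600 nM. On the numbers shown compound 2 stands with the higher of the two values, but the gap to compound 1, its only neighbour, lies within the scatter, so the two cannot be told apart on this read-out.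

Compound 3 `Cc1ccc(C(C)C)c(OC(=O)c2cn(-c3ccccc3)nc2-c2cccnc2)c1` is not yet measured. It differs from compound 2 in one place: 2-isopropyl-5-methylphenyl in place of 3-isopropylphenyl on an oxygen next to a carbonyl group. Among the measured compounds shown here, no step between measured compounds touches this position, so the data give no direction for the change. A step of this kind is expected to stay within the scatter, with no clear direction; the expected step from compound 2 to compound 3 is a 1.2-fold lower number from compound 2 to compound 3 (0.06 log units; within the scatter). For compound 3 in this assay the estimate is 10000 nM, with a range from 4000 nM to 25000 nM.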

Compound 3, half-maximal inhibitory concentration: 20600 nM
Compound 3: the middle estimate sits 2.1-fold (0.31 log units) below what was measured, and the stated range covers the measured number.
By their numbers in this assay, from the lowest: compounds 1, 2 and 3 (each within the scatter of the next, the first and the last beyond it).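

In this assay, among the compounds shown here, 2-isopropyl-5-methylphenyl in place of 3-isopropylphenyl on an oxygen next to a carbonyl group gives a 1.8-fold higher number from compound 2 to compound 3 (0.25 log units; within the scatter) and is the first step that reads this position directly, since the earlier compounds offered no pair differing there. With the enlarged aryl group, which has 10 heavy atoms against 9, the two esters still cannot be told apart on this read-out. The position therefore has one reading so far, and that reading sets no direction for further changes. Nothing shown explains the result of this exchange.

For the compounds shown here, the single step leaves open how the added methyl and the different placement of the isopropyl group each contribute, since both are contained in the one exchange. It also leaves open whether a phenyl ring bearing an amine or a carboxylic acid in place of the isopropyl group would separate from compound 2 beyond the scatter in this assay on this series.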